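The compounds below may be only part of what the source reports. "The series", "measured", "known", "first", "only" and "open" are said of these compounds alone.

Compound 1 `COc1ccc([C@H]2CC(=O)N(c3ccccn3)C2)cc1OC1CCCC1`: > 10000 nM (a limit)
Compound 2 `COc1ccc([C@H]2CC(=O)N(c3cccc([S+](C)[O-])c3)C2)cc1OC1CCCC1`: > 10000 nM (a limit)
Compound 3 `COc1ccc([C@H]2CC(=O)N(c3cccc(NCc4ccoc4)c3)C2)cc1OC1CCCC1`: > 10000 nM (a limit)

These three compounds were tested in a functional assay on HEK293 cells (Homo sapiens) for cytotoxicity; on this read-out lower numbers stand for higher toxicity in this test and higher numbers for lower toxicity in this test. Compound 3 reads > 10000 nM, which is a limit of the assay and not a number. It therefore gives no exact position on the scale, and it shares its standing with the other two compounds: the limit of > 10000 nM in this assay, at which 3 of the 3 values shown sit.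

Compound 4 `COc1ccc([C@H]2CC(=O)N(c3cccc(NS(=O)(=O)c4cccc(Cl)c4C)c3)C2)cc1OC1CCCC1` keeps the shared core and differs from compound 3 in one place: (3-chloro-2-methylphenyl)sulfonyl in place of (furan-3-yl)methyl on a nitrogen on an aromatic ring. Here (3-chloro-2-methylphenyl)sulfonyl stands in place of (furan-3-yl)methyl on a nitrogen on an aromatic ring, so that ((furan-3-yl)methyl)amino becomes ((3-chloro-2-methylphenyl)sulfonyl)amino.

Going by the values given here, two measured steps bear on this change: a step that the two limits leave unreadable from compound 1 to compound 2, and a step that the two limits leave unreadable from compound 2 to compound 3. Neither has a size that can be read, so neither suggests a direction. All three measured compounds nevertheless remain at the same limit despite their different groups, and none goes against this. No step beyond the usual scatter is therefore expected, and another limit is the likeliest report. The expected size of the change is a step that the limit leaves unreadable from compound 3 to compound 4. For compound 4 the estimated value is 15000 nM, with an expected range from 6000 nM to 40000 nM.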

Compound 4, half-maximal cytotoxic concentration: > 10000 nM
Compound 4 ended at the assay's limit (the forecaster's own chance of this, stated with the estimate: 80%); the middle value lies beyond the limit too.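

In this assay compound 4 gives > 10000 nM as a limit of the assay. The steps to compound 4 from compound 2 and from compound 3 cannot be read, so neither has a size. The compounds shown leave open where any of them lies on the scale, and whether any of these groups changes the read-out: the limit of > 10000 nM in this assay, at which 4 of the 4 values shown sit.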